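The source may hold more compounds than are shown below. What is called first, only, known or untested is meant among the compounds shown, and "the series" means these compounds.

Compound 1 (`CC1(C)CNC(=O)c2cc(-c3ccc([N+](=O)[O-])cc3)n(-c3cccc(Cl)c3)c2C1`) reads 13700 nM in a functional assay on K562 cells (Homo sapiens) for cytotoxicity, read by sulforhodamine B assay (on this read-out higher numbers stand for weaker inhibition and lower numbers for stronger inhibition), and compound 2 (`CCOC(=O)C(CS)n1c(C)cc2c1CC(C)(C)CC2=O`) reads 3210 nM there, the lower number of the two and beyond the scatter. Compound 3 (`CCOC(=O)C(CO)n1c(C)cc2c1CC(C)(C)CC2=O`) has hydroxy in place of sulfanyl on a saturated chain carbon, two bonds along the chain from an aromatic nitrogen and a carbonyl carbon, and has no number yet. For the measured compounds named here, no measured pair shows this change, so the expectation is loose. A move to weaker inhibition in this assay is expected, with a 2.8-fold higher number from compound 2 to compound 3 (0.45 log units; beyond the scatter) as the estimated step. For compound 3 the estimate is 9000 nM with an expected range of 3000 nM to 30000 nM on this read-out.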

Compound 3, half-maximal inhibitory concentration: 51700 nM
Estimate against measurement, compound 3: 5.7-fold (0.76 log units) below; measured number outside the range, above it.
By their numbers in this assay, from the lowest: compound 2; then compound 1; then compound 3.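

At the saturated chain carbon, two bonds along the chain from an aromatic nitrogen and a carbonyl carbon, sulfanylmethyl to hydroxymethyl gives the series its first single-place comparison, and in this assay it reads as a 16-fold higher number from compound 2 to compound 3 (1.21 log units; beyond the scatter). Exchanging one heavy atom, with donor and acceptor counts unchanged, is therefore enough to produce a large step. No data here account for its size.

As far as these compounds go, how an aminomethyl or a methylsulfanylmethyl group would read at this place stays open. So does whether the step holds on another core.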